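Cyclohexyl for isopropyl beside the primary amine

A few compounds are considered here, and "the series" means these few. Any claim that something is new, unique, unknown or untested is made for them only; others in the source may bear on it.

Compound 2 `COc1cccc(-c2c(C)n(Cc3c(F)cccc3F)c(=O)n(C[C@H](N)C(C)C)c2=O)c1F` gives 51 nM in an assay on HEK293 cells for binding affinity to Gonadotropin-releasing hormone receptor (Homo sapiens), read by radioligand binding (on this read-out lower numbers stand for stronger inhibition and higher numbers for weaker inhibition), the second highest of the three numbers. Compound 1 `COc1cccc(-c2c(C)n(Cc3c(F)cccc3F)c(=O)n(C[C@@H](N)CCc3ccccc3)c2=O)c1F` gives 965 nM and compound 3 `COc1cccc(-c2c(C)n(Cc3c(F)cccc3F)c(=O)n(C[C@@H](C3CCCCC3)N(C)C)c2=O)c1F` gives 4.1 nM; the steps of a 19-fold lower number from compound 1 to compound 2 (1.28 log units; beyond the scatter) and a 12-fold lower number from compound 2 to compound 3 (1.09 log units; beyond the scatter) show that this side chain moves the read-out strongly. Compound 4 `COc1cccc(-c2c(C)n(Cc3c(F)cccc3F)c(=O)n(C[C@@H](N)C3CCCCC3)c2=O)c1F` carries amino(cyclohexyl)methyl in place of 1-amino-2-methylpropyl on a saturated chain carbon bound to an aromatic nitrogen. Among the compounds with values here, the step from compound 2 to compound 3 bears on it most closely, but compound 3 carries the dimethylamino form whereas compound 4 keeps the amino form, and no measured pair separates the two changes. For compound 4 a lower number is expected, a step of a 3.4-fold lower number from compound 2 to compound 4 (0.53 log units; beyond the scatter), likely short of the full gain seen with compound 3. Compound 4 is estimated at 15 nM, within 4 nM to 60 nM.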

Compound 4, inhibition constant: 46 nM
Estimate against measurement, compound 4: 3.1-fold (0.49 log units) below; the measured number falls inside the stated range.
By their numbers in this assay, from the lowest: compound 3; then compounds 4 and 2 (each within the scatter of the next); then compound 1.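

Replacing 1-amino-2-methylpropyl with amino(cyclohexyl)methyl while keeping the primary amine gives a 1.1-fold lower number from compound 2 to compound 4 (0.04 log units; within the scatter) in this assay, so this change alone does not separate these compounds. With cyclohexyl common to both, the change from the dimethylamino form to the primary amine gives an 11-fold higher number from compound 3 to compound 4 (1.05 log units; beyond the scatter) and isolates the amine as the site of that large step. The primary amines are not all alike, as a 21-fold lower number from compound 1 to compound 4 (1.32 log units; beyond the scatter) sets the phenethyl-bearing chain apart. No measurement shown accounts for these steps. Open, from the compounds shown here alone, is whether a methylamino group would retain the number of compound 3, and whether dimethylamino on the 1-amino-2-methylpropyl chain would produce a similar step.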